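Hydroxy for hydroxymethyl on the side chain of compound 2

A few compounds are considered here, and "the series" means these few. Any claim that something is new, unique, unknown or untested is made for them only; others in the source may bear on it.

Within the data shown here, in a physicochemical assay for lipophilicity, at pH 7.4 (a lower number here means a more polar compound, a higher number a more lipophilic compound), two compounds with a shared core have numbers so far. Compound 1 `C[C@H]1C(=O)N(C)C=Cc2cc(CN3CCCC3)ccc21`, with (pyrrolidin-1-yl)methyl on an aromatic carbon, gives 1.5. Compound 2 `C[C@H]1C(=O)N(C)C=Cc2cc(C(CO)CO)ccc21`, with 2-hydroxy-1-(hydroxymethyl)ethyl in its place, gives 1.2. The measured step is a number 0.30 log units lower from compound 1 to compound 2 (within the scatter), so compound 2 stands level with compound 1 on the numbers available.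

Compound 3 `C[C@H]1C(=O)N(C)C=Cc2cc(C(O)CO)ccc21` differs from compound 2 in one place: hydroxy in place of hydroxymethyl on a saturated chain carbon bound to an aromatic carbon and a saturated chain carbon. Hydroxy stands in place of hydroxymethyl on a saturated chain carbon bound to an aromatic carbon and a saturated chain carbon, which turns 2-hydroxy-1-(hydroxymethyl)ethyl into 1,2-dihydroxyethyl. Among the measured compounds shown here, no measured step makes this exchange, so the one step to compound 2 is only a loose guide. That step exchanged the whole group, and it stayed within the scatter at a number 0.30 log units lower from compound 1 to compound 2 (within the scatter). A smaller exchange is therefore expected to give no larger a move. The expected change is a number 0.20 log units lower from compound 2 to compound 3 (within the scatter), a small downward step that is not expected to clear the scatter. Compound 3 is estimated at 1, with an expected range from 0.6 to 1.4.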

Compound 3, distribution coefficient: 1.1
Compound 3: middle estimate off by 0.10 log units, on the low side; low and high end bracket the measured number.
By their numbers in this assay, from the lowest: compounds 3, 2 and 1 (each within the scatter of the next, the first and the last beyond it).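

In this assay, the exchange of hydroxymethyl for hydroxy on a saturated chain carbon bound to an aromatic carbon and a saturated chain carbon gives a number 0.10 log units lower from compound 2 to compound 3 (within the scatter), so compound 3 stands level with compound 2 and the side chain tolerates this exchange with no measurable move. Set against (pyrrolidin-1-yl)methyl on the aromatic carbon, 1,2-dihydroxyethyl gives a number 0.40 log units lower from compound 1 to compound 3 (beyond the scatter), which makes this the first step at that position to clear the scatter, where 2-hydroxy-1-(hydroxymethyl)ethyl, with a number 0.30 log units lower from compound 1 to compound 2 (within the scatter), did not. No evidence is available that bears on the reason for these numbers.

The compounds shown leave open whether a carboxylic acid or a primary amine on the same aromatic carbon would stand further from compound 1 than 1,2-dihydroxyethyl does, or level with it. They also leave open whether a longer chain carrying hydroxy would stand level with compound 3, and whether the exchange of hydroxymethyl for hydroxy would read the same on another core.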